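Branching on the amide nitrogen of adenosine-derived amides

The source may hold more compounds than are shown below. What is called first, only, known or untested is meant among the compounds shown, and "the series" means these compounds.

Measured compounds:
- compound 1 `CCCCNC(=O)[C@H]1OC(n2cnc3c(N)ncnc32)[C@H](O)[C@@H]1O`: 17 nM
- compound 2 `CCC(C)NC(=O)[C@H]1OC(n2cnc3c(N)ncnc32)[C@H](O)[C@@H]1O`: 198 nM
- compound 3 `CC(=O)NCCNC(=O)[C@H]1OC(n2cnc3c(N)ncnc32)[C@H](O)[C@@H]1O`: 46 nM

In an assay on cell membranes for binding affinity to 2-oxoglutarate receptor 1 (Rattus norvegicus), read by radioligand binding (a higher number here means a weaker inhibitor, a lower number a stronger inhibitor), compound 3 stands second highest of the three numbers, nearest to compound 1 and furthest from compound 2 (a 4.3-fold lower number from compound 2 to compound 3 (0.63 log units; beyond the scatter)). Compound 4 `CC1CCCCC1NC(=O)[C@H]1OC(n2cnc3c(N)ncnc32)[C@H](O)[C@@H]1O` differs from compound 3 by 2-methylcyclohexyl in place of 2-acetamidoethyl on an amide-type nitrogen. The step that bears most on this change is a 12-fold higher number from compound 1 to compound 2 (1.07 log units; beyond the scatter), a large loss on moving to a group branched at the carbon bound to the nitrogen; the step of a 2.7-fold higher number from compound 1 to compound 3 (0.43 log units; beyond the scatter) was modest. Since the 2-methylcyclohexyl group is likewise branched at that carbon, a higher number is expected for compound 4, about a 6.5-fold higher number from compound 3 to compound 4 (0.81 log units; beyond the scatter). Compound 4 is therefore estimated at 300 nM, with a range from 80 nM to 1200 nM.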

Compound 4, inhibition constant: 69.5 nM
The estimate for compound 4 lay 4.3-fold (0.64 log units) above the measured number; the measured number lies below the stated range.
By their numbers in this assay, from the lowest: compound 1; then compounds 3 and 4 (each within the scatter of the next); then compound 2.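

On the amide-type nitrogen, 2-methylcyclohexyl and 2-acetamidoethyl cannot be told apart (a 1.5-fold higher number from compound 3 to compound 4 (0.18 log units; within the scatter)), although the first has no hydrogen-bond donor or acceptor and the second has one of each. Branching as such therefore does not fix the loss seen with sec-butyl (a 2.8-fold lower number from compound 2 to compound 4 (0.45 log units; beyond the scatter)), yet butyl keeps its lead (a 4.1-fold higher number from compound 1 to compound 4 (0.61 log units; beyond the scatter)). Nothing measured beyond these numbers explains the steps. On these data alone, it remains open whether the ring or its methyl accounts for the gain over sec-butyl, which plain cyclohexyl would address. Whether pentyl would surpass butyl is also unresolved.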